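Limits and a Single Number in an Antiproliferative Series

The source may hold more compounds than are shown below. What is called first, only, known or untested is meant among the compounds shown, and "the series" means these compounds.

Measured in a functional assay on HeLa cells (Homo sapiens) for antiproliferative activity, read by sulforhodamine B assay, with a stated time of 72 h; on this read-out lower numbers stand for stronger inhibition and higher numbers for weaker inhibition:
- compound 1 `COc1ccccc1NC(=S)N/N=C/c1ccc2ccccc2n1`: > 100000 nM (a limit)
- compound 2 `CN(C)C(=S)N/N=C/c1ccc2ccccc2n1`: 90 nM
- compound 3 `COc1ccc(C)cc1NC(=S)N/N=C/c1ccc2ccccc2n1`: > 100000 nM (a limit)

In this assay compound 1 gives > 100000 nM, which is a limit and not a number. Compound 3 gives > 100000 nM, which is also a limit. Of the three, only compound 2 gives a number, 90 nM.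

Compound 4 `N#Cc1ccc(NC(=S)N/N=C/c2ccc3ccccc3n2)cc1` has not yet been measured. It changes compound 1 in one place: 4-cyanophenyl in place of 2-methoxyphenyl on an amide-type nitrogen. The 4-cyanophenyl stands on the same amide-type nitrogen that carries 2-methoxyphenyl in compound 1.

Going by the values given here, only one measured step bears on this, and it gives no size to carry over: a step that the two limits leave unreadable from compound 1 to compound 3. Compound 1 stands at the limit of > 100000 nM in this assay, at which 2 of the 3 values shown sit, so the expectation for compound 4 is that it stays weak and may well reach the same limit. Compound 2 goes against any reading of the series as uniformly weak, so some gain in this assay cannot be excluded, and any change is expected toward stronger inhibition. The expected change is an at least 3.3-fold lower number from compound 1 to compound 4 (0.52 log units; beyond the scatter), a rough estimate only. For compound 4 the estimated value is 30000 nM, with an expected range from 2000 nM to 100000 nM.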

Compound 4, half-maximal inhibitory concentration: 20000 nM
Compound 4: the middle estimate sits 1.5-fold (0.18 log units) above what was measured, and the stated range covers the measured number.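

In this assay, 4-cyanophenyl in place of 2-methoxyphenyl on the amide-type nitrogen gives an at least 5.0-fold lower number from compound 1 to compound 4 (0.69 log units; beyond the scatter), the first step among these aryl compounds that can be read at all; the earlier step, with methyl in place of hydrogen on an aromatic carbon, cannot be read. This shows that the aryl group on this nitrogen is a place where the read-out can move off the limit while the rest of compound 1 stays the same, even though the two groups match in heavy atoms and in the donors and acceptors counted for them. Compound 1 is held at a limit, so the step gives only a lower bound on the size of the change: the limit of > 100000 nM in this assay, at which 2 of the 4 values shown sit.

The change removes the methoxy and brings in the nitrile in a single move, so the compounds shown cannot tell whether losing the one or gaining the other carries the step. From the compounds shown here alone, how a plain phenyl on this nitrogen would read stays open, as does the effect of an amine or a carboxylic acid on that phenyl.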